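Halogen exchange on the fused ring of compound 2

The compounds below may be only part of what the source reports. "The series", "measured", "known", "first", "only" and "open" are said of these compounds alone.

Compound 1 `CC#C[C@@H](CC(=O)O)c1ccc(OC[C@H]2COc3cccc(Cl)c3O2)cc1` and compound 2 `CC#C[C@@H](CC(=O)O)c1ccc(OC[C@H]2COc3cc(F)c(Cl)cc3O2)cc1` share one core and differ only on the fused ring. In a functional assay on HEK293 cells for agonist activity at Free fatty acid receptor 1 (Homo sapiens), read by fluorescence and calcium flux, with a stated time of 10 min (on this read-out higher numbers stand for larger maximal responses and lower numbers for smaller maximal responses), compound 1 gives 95%, while in this assay compound 2 gives 46%. Compound 2 thus stands lowest of the two measured numbers, with compound 1 higher by a margin beyond the usual scatter of repeated measurements. Compound 3 `CC#C[C@@H](CC(=O)O)c1ccc(OC[C@H]2COc3cc(Br)c(Cl)cc3O2)cc1` has not yet been measured. It differs from compound 2 in one place: bromo in place of fluoro on an aromatic carbon. Among the compounds with values here, no measured pair carries a bromo group, so the two values of compound 1 and compound 2 are the only guide. The expected step of a number 1 percentage points lower from compound 2 to compound 3 (within the scatter) in this assay is none beyond the scatter, with no direction favoured. Compound 3 is therefore estimated to give about 45% in this assay, with a likely range from 20% to 75%.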

Compound 3, largest response reached (Emax), in percent of the reference or control that the assay uses: 82%
Compound 3: middle estimate off by 37 percentage points, on the low side; the measured number lies above the stated range.
By their numbers in this assay, from the lowest: compound 2; then compound 3; then compound 1.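

On this aromatic carbon, ortho to a chloro group, the identity of the halogen matters: bromo in place of fluoro gives a number 36 percentage points higher from compound 2 to compound 3 (beyond the scatter) in this assay. Within the data shown here, as the only one-place pair, compound 2 and compound 3 show that this position responds to the exchange of a single atom, with the counts of rings, hydrogen-bond donors and hydrogen-bond acceptors left unchanged. Nothing available accounts for the size of this step.

One pair leaves open how chloro, methoxy or nitrile would behave on the same carbon, and so whether the response follows any order across groups. Also open, as far as these compounds go, is whether the step from fluoro to bromo would persist if an amine stood in place of the chloro group.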